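A few compounds are considered here, and "the series" means these few. Any claim that something is new, unique, unknown or untested is made for them only; others in the source may bear on it.

Working notes on the series. In a physicochemical assay for lipophilicity, at pH 7.4 (on this read-out lower numbers stand for lower lipophilicity and higher numbers for higher lipophilicity), compound 1 `CNC(=O)c1cc(C(=O)NC2CCC2)cn(Cc2cccc(NC)c2)c1=O` gives 3.6, and compound 2 `CNC(=O)c1cc(C(=O)NC2CC2)cn(Cc2ccc3nc[nH]c3c2)c1=O` gives 1.2, the lower of the two numbers, with compound 1 standing above it by a gap beyond the usual scatter. Compound 3 `CNC(=O)c1cc(C(=O)NC2CC2)cn(Cc2cccc(C#N)c2)c1=O` is not yet measured; it differs from compound 2 by 3-cyanophenyl in place of 1H-benzimidazol-6-yl on a saturated chain carbon bound to an aromatic nitrogen. Going by the values given here, no measured pair isolates this change, so the expected step rests on the two numbers alone. Relative to compound 2, the step from compound 2 to compound 3 is expected to be an increase of about a number 1.10 log units higher from compound 2 to compound 3 (beyond the scatter) in this assay. Compound 3 is thus estimated at 2.3, with a range from 1.6 to 3.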

Compound 3, distribution coefficient: 2.6
Beside the measured number, compound 3's estimate is 0.30 log units below it; the range from low to high includes it.
By their numbers in this assay, from the lowest: compound 2; then compound 3; then compound 1.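

In this assay, the aryl group on a saturated chain carbon bound to an aromatic nitrogen has a large effect: 3-cyanophenyl in place of 1H-benzimidazol-6-yl gives a number 1.40 log units higher from compound 2 to compound 3 (beyond the scatter). Going by these compounds alone, this is the first pair that differs in one place, so the size of a change here can be read directly. Nothing measured on these compounds accounts for the step. Still open, on these data alone, is whether the step belongs to the nitrile or to the loss of the five-membered aromatic ring. Plain phenyl, or phenyl carrying an amine or a carboxylic acid, would test this.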